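The source may hold more compounds than are shown below. What is called first, only, known or untested is meant among the compounds shown, and "the series" means these compounds.

Compound 1, `CCCNNC(=O)c1ccc(CNC(=O)c2cc3cc(Cl)ccc3o2)cc1`, gives > 10000 nM in an assay on isolated protein for inhibition of protein deacetylase HDAC6 (Homo sapiens), read by fluorescence, with a stated time of 2 h (a higher number here means a weaker inhibitor, a lower number a stronger inhibitor), a limit of the assay.
Compound 2, `CCCNNC(=O)c1ccc(CNC(=O)c2cc3cc(Br)ccc3o2)cc1`, gives > 10000 nM in this assay, again a limit.

Compound 2 thus stands at the limit described by the limit of > 10000 nM in this assay, at which 2 of the 2 values shown sit. Compound 1 stands at the same limit. The step that the two limits leave unreadable from compound 1 to compound 2 cannot be read from two limits. Compound 3, `CCCNNC(=O)c1ccc(CNC(=O)c2cc3cc(OC)ccc3o2)cc1`, differs from compound 2 in that (methoxy in place of bromo on an aromatic carbon). Among the measured compounds shown here, the only measured step bears on this change but has no readable size, so no direction can be taken from it. Compound 3 is therefore expected to remain near the limit, at an estimated 20000 nM (range 5000 nM to 80000 nM), an expected step that the limit leaves unreadable from compound 2 to compound 3.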

Compound 3, half-maximal inhibitory concentration: > 10000 nM
Compound 3 gave a limit, no number (the forecaster's own chance of this, stated with the estimate: 75%); the middle value does not contradict the limit.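

Compound 3 also gives a limit, so no step among compound 1, compound 2 and compound 3 can be read: the limit of > 10000 nM in this assay, at which 3 of the 3 values shown sit.

The compounds shown leave open how chloro, bromo and methoxy on the shared core compare in this assay.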